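From 4-bromophenyl to 4-amino-2-fluorophenyl on the sulfonyl sulfur

A few compounds are considered here, and "the series" means these few. Any claim that something is new, unique, unknown or untested is made for them only; others in the source may bear on it.

Three compounds share one core and differ only in the aromatic group on the sulfonyl sulfur: compound 1 `Cn1c(=O)c(S(=O)(=O)c2ccc(Cl)cc2)cc2cnc(Nc3ccc4[nH]ccc4c3)nc21`, compound 2 `Cc1ccc(S(=O)(=O)c2cc3cnc(Nc4ccc5[nH]ccc5c4)nc3n(C)c2=O)cc1` and compound 3 `Cn1c(=O)c(S(=O)(=O)c2ccc(Br)cc2)cc2cnc(Nc3ccc4[nH]ccc4c3)nc21`. In a functional assay on K562 cells (Homo sapiens) for inhibition, read by trypan blue exclusion, with a stated time of 72 h (on this read-out higher numbers stand for weaker inhibition and lower numbers for stronger inhibition), compound 1 gives 100 nM, compound 2 gives 750 nM and compound 3 gives 5000 nM. Compound 3 therefore holds the highest number of the three and is the weakest inhibitor among them.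

The next compound is compound 4 `Cn1c(=O)c(S(=O)(=O)c2ccc(N)cc2F)cc2cnc(Nc3ccc4[nH]ccc4c3)nc21`, with 4-amino-2-fluorophenyl in place of 4-bromophenyl on a sulfonyl sulfur.

All three measured steps concern this same aromatic group. Bromo in place of chloro gives a 50-fold higher number from compound 1 to compound 3 (1.70 log units; beyond the scatter), methyl in place of chloro gives a 7.5-fold higher number from compound 1 to compound 2 (0.88 log units; beyond the scatter), and bromo in place of methyl gives a 6.7-fold higher number from compound 2 to compound 3 (0.82 log units; beyond the scatter). Single exchanges here thus produced modest to large steps, all beyond the scatter. Going by the values given here, no measured compound carries an amino or a fluoro group, so these steps give only a rough guide to size and direction.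

With compound 3 at the top of the range, a modest step towards a lower number is expected in this assay. The expected step is a 13-fold lower number from compound 3 to compound 4 (1.10 log units; beyond the scatter). The estimate for compound 4 is 400 nM, with an expected range of 50 nM to 3000 nM.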

Compound 4, half-maximal inhibitory concentration: 1500 nM
For compound 4 the middle estimate is 3.8-fold (0.57 log units) below the measured one; measured number inside the range.
By their numbers in this assay, from the lowest: compound 1; then compounds 2 and 4 (each within the scatter of the next); then compound 3.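

Replacing 4-bromophenyl with 4-amino-2-fluorophenyl on the sulfonyl sulfur lowers the number in this assay (a 3.3-fold lower number from compound 3 to compound 4 (0.52 log units; beyond the scatter)), so a group bearing a hydrogen-bond donor and no chloro, bromo or methyl group still gives a measurable effect in this series and does not mark the weak end of the range. It does not match the 4-chlorophenyl group (a 15-fold higher number from compound 1 to compound 4 (1.18 log units; beyond the scatter)), which leaves compound 1 the strongest inhibitor of the four, while it cannot be ordered against 4-methylphenyl (a 2.0-fold higher number from compound 2 to compound 4 (0.30 log units; within the scatter)), so the two quite different groups are not separated by this read-out. The compounds shown give no evidence on the reason for any of these steps.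

Compound 4 changes two things on the ring at once, so the shares of the amino and fluoro groups in its step stay unresolved, and a ring with only one of the two would be needed to separate them. From the compounds shown here alone, how a methoxy group, a carboxylic acid or a dimethylamino group would behave on the same aromatic ring also stays open, as does whether the sharp gap between the chloro and bromo compounds recurs elsewhere.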